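Small Changes on Sulfur in a Short-Lived Series

A few compounds are considered here, and "the series" means these few. Any claim that something is new, unique, unknown or untested is made for them only; others in the source may bear on it.

In an ADME assay on microsomes from liver (Mus musculus, strain CD-1) for metabolic stability, read by LC-MS, with a stated time of 60 min, tested at 20 uM (on this read-out higher numbers stand for a longer-lived compound and lower numbers for a shorter-lived compound), compound 1 (`C[C@@H](Sc1nc2c(cnn2C)c(=O)n1-c1ccccc1)c1ccccc1`) gives 0.133 h, compound 2 (`CC(Sc1nc2c(cnn2C)c(=O)n1-c1ccccc1)c1cccc(F)c1`) gives 0.133 h and compound 3 (`CC(Sc1nc2c(cnn2C)c(=O)n1-c1ccccc1)c1cccnc1`) gives 0.117 h. Compound 3 therefore stands within the scatter of both other compounds. Compound 4 (`Cn1ncc2c(=O)n(-c3ccccc3)c(SCc3cccc(F)c3)nc21`) keeps the shared core but carries a different group on the sulfur: 3-fluorobenzyl in place of 1-(pyridin-3-yl)ethyl on a sulfur.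

Among the measured compounds shown here, three measured steps bear on this change: no change at the digits printed from compound 1 to compound 2 (within the scatter), a 1.1-fold lower number from compound 1 to compound 3 (0.06 log units; within the scatter) and a 1.1-fold lower number from compound 2 to compound 3 (0.06 log units; within the scatter). Each of them exchanged the ring on the group attached to sulfur, and none went beyond the scatter. For the measured compounds named here, no measured compound carries the 3-fluorobenzyl group, so the data do not test this exact group, and a surprise remains possible. On the evidence of these three small steps, no change beyond the scatter is expected in this assay. The expected step is a 1.1-fold higher number from compound 3 to compound 4 (0.05 log units; within the scatter). For compound 4 the estimated half-life is 0.13 h, with an expected range from 0.07 h to 0.25 h.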

Compound 4, half-life: 0.133 h
Beside the measured number, compound 4's estimate is 1.0-fold (0.01 log units) below it; the range from low to high includes it.
By their numbers in this assay, from the lowest: compounds 3, 1, 2 and 4 (each within the scatter of the next).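

Hydrogen in place of methyl on the saturated chain carbon bound to an aromatic carbon and a sulfur now has a direct comparison in this assay (no change at the digits printed from compound 2 to compound 4 (within the scatter)), and this step stays within the scatter. The two steps that exchange the whole group on the sulfur (no change at the digits printed from compound 1 to compound 4 (within the scatter); a 1.1-fold higher number from compound 3 to compound 4 (0.06 log units; within the scatter)) also stay within the scatter, so among these four compounds neither that methyl nor the exchange of rings separates the half-lives. Nothing available explains why these numbers stay so close.

From the compounds shown here alone, all four compounds keep an aromatic ring in the group on the sulfur, so it remains open whether a longer chain, an amine or a carboxylic acid in that place would give a different half-life. Going by these compounds, the effect of changes elsewhere on the shared core also remains open.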